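Thioacetate Series: From Acid to Chloroanilide

The compounds below may be only part of what the source reports. "The series", "measured", "known", "first", "only" and "open" are said of these compounds alone.

Values in a functional assay on KB cells (Homo sapiens) for inhibition, read by MTT assay, with a stated time of 24 h, tested at 1 ug/mL; on this read-out lower numbers stand for less inhibition of growth and higher numbers for more inhibition of growth at the one concentration tested:
- compound 1 `CC(=O)SCCC(CCCCC(=O)O)SC(C)=O` gives 12.4%
- compound 2 `O=C(CCCCC1CCSS1)Nc1ccc([N+](=O)[O-])c(C(F)(F)F)c1` gives "not active" (no number reported)
- compound 3 `O=C(CCCCC(S)CCS)Nc1ccc(OC(F)(F)F)cc1` gives 6%

Compound 1 at 12.4% and compound 3 at 6% lie within the scatter of each other, and compound 2 has no number. Compound 4 `CC(=O)SCCC(CCCCC(=O)Nc1ccccc1Cl)SC(C)=O` keeps the core of compound 1 and carries (2-chlorophenyl)amino in place of hydroxy on a carbonyl carbon, that is, (2-chlorophenyl)amino in place of hydroxy on a carbonyl carbon. Among the measured compounds shown here, no measured pair isolates this change. Compound 3, also an amide bearing an aromatic ring, gives only 6%, so no step beyond the scatter is expected in this assay, and no direction is favoured. The expected change is a number 0.6 percentage points higher from compound 1 to compound 4 (within the scatter). For compound 4 the estimate is 13%, with an expected range from 2% to 35%.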

Compound 4, percent growth inhibition at one concentration: 8.21%
For compound 4 the middle estimate is 4.8 percentage points above the measured one, within the range that was stated.
By their numbers in this assay, from the lowest: compounds 3, 4 and 1 (each within the scatter of the next).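

With (2-chlorophenyl)amino in place of hydroxy on a carbonyl carbon, this assay gives a number 4.2 percentage points lower from compound 1 to compound 4 (within the scatter) as the only step shown between compounds that differ in one place. At this carbonyl carbon, the read-out at the one concentration tested therefore does not separate the carboxylic acid from the chloroanilide. No measurement shown accounts for this result.

The compounds shown leave open how a methyl ester or an unsubstituted phenylamino group would read at this carbonyl carbon. Going by these compounds, a piperidine amide at the same place also remains open.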